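A few compounds are considered here, and "the series" means these few. Any claim that something is new, unique, unknown or untested is made for them only; others in the source may bear on it.

In a toxicity assay on MRC5 cells (Homo sapiens) for inhibition, read by MTT assay, with a stated time of 72 h (a lower number here means a stronger inhibitor, a higher number a weaker inhibitor), compound 1 `CCCCCCCCCCCCCC(=O)OCCc1ccc(O)c(O)c1` gives > 50000 nM, which is a limit of the assay and not a number. Compound 1 therefore sits at the limit of > 50000 nM in this assay, at which 2 of the 3 values shown sit. Compound 3 `CCCCCCCCCCCCSCCc1ccc(OCc2ccccc2)c(OCc2ccccc2)c1` gives > 50000 nM, also a limit. Among the measured compounds shown here, compound 2 `CCCCCC(=O)OCCc1ccc(O)cc1` is the only one with a measured number, 166000 nM. Compound 4 `CCCCCCCCCC(=O)OCCc1ccc(O)c(O)c1` differs from compound 1 by hydrogen in place of butyl on a saturated chain carbon, nine bonds along the chain from a carbonyl carbon, with hydrogen in place of butyl on a saturated chain carbon, nine bonds along the chain from a carbonyl carbon. For the measured compounds named here, no measured pair shows this change alone, so in this assay no step beyond the scatter is expected, in either direction. The expected step is a step that the limit leaves unreadable from compound 1 to compound 4. Compound 4 is estimated at 80000 nM, with an expected range from 30000 nM to 200000 nM.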

Compound 4, half-maximal inhibitory concentration: 71100 nM
Beside the measured number, compound 4's estimate is 1.1-fold (0.05 log units) above it; the measured number falls inside the stated range.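

The size of any change from compound 1 to compound 4 cannot be read, because the value of compound 1 is a limit and not a number: the limit of > 50000 nM in this assay, at which 2 of the 4 values shown sit.

On these data alone, whether hydrogen in place of butyl on the chain changes the toxicity at all stays open.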